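Bromo for Trifluoromethyl Beneath a Cytotoxicity Ceiling

A few compounds are considered here, and "the series" means these few. Any claim that something is new, unique, unknown or untested is made for them only; others in the source may bear on it.

Measured compounds:
compound 1 `O=C1N(CCCCCCOc2ccc(Br)cc2)CCN1c1ccncc1`: in a functional assay on cells (Homo sapiens) for cytotoxicity (a higher number here means that more compound is tolerated, a lower number that less compound is tolerated), compound 1 gives > 25000 nM, a limit of the assay.
compound 2 `O=C1N(CCCCCCOc2ccc(Br)cc2)CCN1c1cccnc1`: in this assay compound 2 gives > 25000 nM, again a limit.
compound 3 `O=C1N(CCCCCCOc2ccc(C(F)(F)F)cc2)CCN1c1ccncn1`: in this assay compound 3 gives > 25000 nM, also a limit.

Within the data shown here, the one step between measured neighbours, a step that the two limits leave unreadable from compound 1 to compound 2, cannot be read, since both ends are limits. Compound 3 therefore stands exactly where the others stand: the limit of > 25000 nM in this assay, at which 3 of the 3 values shown sit.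

Compound 4 `O=C1N(CCCCCCOc2ccc(Br)cc2)CCN1c1ccncn1` is not yet measured. It differs from compound 3 by bromo in place of trifluoromethyl on an aromatic carbon. Among the measured compounds shown here, no measured step bears on this change, and the single measured step is unreadable, so no shift beyond the scatter is expected in this assay; the expected step is a number no higher from compound 3 to compound 4 (the limit leaves the size open). Compound 4 is estimated at 25000 nM, within 12000 nM to 50000 nM, most likely reported as a limit once more.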

Compound 4, half-maximal cytotoxic concentration: > 25000 nM
Compound 4 was reported as a limit (the forecaster's own chance of this, stated with the estimate: 85%); the middle value lies on the limit itself.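

Among these compounds, no step from compound 1, compound 2 or compound 3 to compound 4 can be read, since every value is a limit: the limit of > 25000 nM in this assay, at which 4 of the 4 values shown sit. The compounds shown leave open whether bromo in place of trifluoromethyl, or any change of the ring on the amide-type nitrogen, alters cytotoxicity at all.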